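Adding a Methyl to an Inactive Nitro-Sulfone Amide

The source may hold more compounds than are shown below. What is called first, only, known or untested is meant among the compounds shown, and "the series" means these compounds.

Compound 1 `CS(=O)(=O)c1ccc(C(=O)N2CCC(C(=O)N3CCc4ccccc43)CC2)cc1[N+](=O)[O-]` was tested in an assay on isolated protein for inhibition of thyroid hormone receptor alpha (Homo sapiens), read by fluorescence polarization (a lower number here means a stronger inhibitor, a higher number a weaker inhibitor), where the test reports a limit rather than a number for compound 1, namely > 60000 nM. Compound 2 `CCCN(C(=O)CN(C)C(=O)c1ccc(S(C)(=O)=O)c([N+](=O)[O-])c1)c1ccccc1` likewise reaches only a limit in this assay, > 60000 nM. Compound 3 `CC(C)N(C(=O)CNC(=O)c1ccc(S(C)(=O)=O)c([N+](=O)[O-])c1)C(C)C` also stops at a limit in this assay, giving > 60000 nM. So compound 1 cannot be placed above or below compounds 2 and 3: all three sit at the same limit, as summed up by the limit of > 60000 nM in this assay, at which 3 of the 3 values shown sit, and no step between any pair of them can be measured or ranked.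

Compound 4 `CC1Cc2ccccc2N1C(=O)C1CCN(C(=O)c2ccc(S(C)(=O)=O)c([N+](=O)[O-])c2)CC1` has not yet been measured. It differs from compound 1 by methyl in place of hydrogen on a saturated ring carbon, in words a methyl in place of hydrogen on a saturated ring carbon. Among the measured compounds shown here, because the three compounds that share this core all sit at the limit described in the limit of > 60000 nM in this assay, at which 3 of the 3 values shown sit, there is no measured step to suggest that so small an addition would move the reading beyond the usual scatter. The expected step from compound 1 to compound 4 is therefore a step that the limit leaves unreadable from compound 1 to compound 4, that is, essentially none. Compound 4 is estimated at 80000 nM in this assay, with an expected range from 30000 nM to 300000 nM, and most likely the assay will again report only a limit.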

Compound 4, half-maximal inhibitory concentration: > 60000 nM
Compound 4 ended at the assay's limit (the forecaster's own chance of this, stated with the estimate: 85%); the middle value is on the limit's open side.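

In this assay compound 4 gives > 60000 nM, which is a limit of the assay and not a number. Compound 1 also stops at a limit, so no step can be read from compound 1 to compound 4: the limit of > 60000 nM in this assay, at which 4 of the 4 values shown sit. The compounds shown leave open whether the methyl changes inhibition at all, and what real value any of these compounds has.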